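A Four-Membered Ring on the Amide of Compound 1

This account rests on a few compounds, and the source may have more. Where it says the series, first, only, none or still open, it means among the compounds named here.

In a physicochemical assay for solubility (on this read-out lower numbers stand for lower solubility and higher numbers for higher solubility), compound 1 `C[C@@H](CO)Oc1cc(Oc2ccc(C(=O)N(C)C)cc2)cc(C(=O)Nc2ccn(C)n2)c1` gives > 1000000 nM, which is a limit of the assay and not a number. In the same assay, compound 2 `COC[C@H](C)Oc1cc(Oc2ccc(C(=O)N(C)C)cc2)cc(C(=O)Nc2cc[nH]n2)c1` gives 730000 nM.

Compound 3 `C[C@@H](CO)Oc1cc(Oc2ccc(C(=O)N3CCC3)cc2)cc(C(=O)Nc2ccn(C)n2)c1` keeps the core of compound 1 and differs in one place, with azetidin-1-yl in place of dimethylamino on a carbonyl carbon. Going by the values given here, no measured pair shows this change, so the expectation rests on the limit reading of compound 1 and on the change itself. No step beyond the usual scatter is expected in this assay, and any shift is expected to be slightly downward. The estimated step of an at least 1.2-fold lower number from compound 1 to compound 3 (0.09 log units; that floor lies within the scatter) is therefore small. Compound 3 is expected to read 800000 nM, with an estimated range of 350000 nM to 1000000 nM. A second limit reading would not be a surprise.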

Compound 3, solubility: 350000 nM
Compound 3: middle estimate off by 2.3-fold (0.36 log units), on the high side; the range from low to high includes it.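

In this assay, azetidin-1-yl in place of dimethylamino on a carbonyl carbon brings an at least 2.8-fold lower number from compound 1 to compound 3 (0.45 log units; beyond the scatter). The earlier compounds shown here gave no step at this position, and this one shows that the read-out responds to a change here, since compound 3 gives a number where the parent gives only a limit. The step is a floor and its full size stays unknown, because compound 1 stands at a limit of the assay: the limit of > 1000000 nM in this assay, at which 1 of the 3 values shown sits.

The compounds shown leave open whether the four-membered ring itself matters, which pyrrolidin-1-yl or an open diethylamino group on the same carbonyl carbon would help to settle. They also leave open whether azetidin-1-yl would bring a step of similar direction on compound 2, whose value is a number and not a limit.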